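Notes on a cyclohexyl replacement in the series

The source may report more compounds than this note shows. Statements on the series, on what has been measured and on what is new or still open speak of the compounds shown alone.

In a functional assay on MV4-11 cells (Homo sapiens) for antiproliferative activity, read by luminescence and CellTiter-Glo, with a stated time of 72 h (on this read-out higher numbers stand for weaker inhibition and lower numbers for stronger inhibition), compound 1 `COc1ccc(CN2CC(c3ccc(O)cc3)c3cnc(-c4c(C)noc4C)nc32)cc1` has "not determined" (no result reported) and offers no number for comparison. Compound 2 `CNc1cc(-c2ccc3cnn(Cc4cc(OC)cc(OC)c4)c3c2)cn(C)c1=O` gives 190 nM, the lower of the two numbers available, while compound 3 `CCNc1cc(-c2ccc3cnn(Cc4cc(OC)cc(OC)c4)c3c2)cn(C)c1=O` gives 2590 nM. Compound 4 `CNc1cc(-c2ccc3cnn(CC4CCCCC4)c3c2)cn(C)c1=O` is unmeasured and departs from compound 2 by one change: cyclohexyl in place of 3,5-dimethoxyphenyl on a saturated chain carbon bound to an aromatic nitrogen. Among the compounds with values here, the only measured step, a 14-fold higher number from compound 2 to compound 3 (1.13 log units; beyond the scatter), is large and beyond the scatter, but it is a different change at a different place, so it bears only indirectly. It shows that one small edit to compound 2 can shift the number strongly. Within the data shown here, no measured step covers the replacement on a saturated chain carbon bound to an aromatic nitrogen. A higher number is expected, with an estimated 4.2-fold higher number from compound 2 to compound 4 (0.62 log units; beyond the scatter). For compound 4 the estimate in this assay is 800 nM, with an expected range of 150 nM to 4000 nM.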

Compound 4, half-maximal inhibitory concentration: 2690 nM
Compound 4: middle estimate off by 3.4-fold (0.53 log units), on the low side; the measured number falls inside the stated range.
By their numbers in this assay, from the lowest: compound 2; then compounds 3 and 4 (each within the scatter of the next).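

In this assay the replacement of 3,5-dimethoxyphenyl by cyclohexyl gives a 14-fold higher number from compound 2 to compound 4 (1.15 log units; beyond the scatter) and so is a large step. The number therefore responds strongly at this place too, on a saturated chain carbon bound to an aromatic nitrogen, and not only at the place changed in compound 3. Nothing available accounts for this step. The change removes the aromatic ring and both oxygens together, and the compounds shown do not separate these two differences. Going by these compounds, an unsubstituted phenyl or a methoxyphenyl with a single methoxy group at this place remains open.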